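Replacing the 4-methoxyphenyl group of compound 1

The source may report more compounds than this note shows. Statements on the series, on what has been measured and on what is new or still open speak of the compounds shown alone.

Measured in an ADME assay on Vero cells (Chlorocebus sabaeus) for cytotoxicity, read by resazurin assay, with a stated time of 72 h; a higher number here means a weaker inhibitor, a lower number a stronger inhibitor:
compound 1 `COc1ccc(C(=O)CCN2CCN(c3ccc(F)cc3)CC2)cc1`: 55000 nM
compound 2 `COc1ccc(C(=O)CCN2CCN(c3ccc([N+](=O)[O-])cc3)CC2)cc1`: 587000 nM
compound 3 `COc1ccc(C(=O)CCN2CCN(c3ccc(F)cc3)CC2)cc1OC`: 175000 nM

Compound 1 has the lowest number of these three. Compound 4 `O=C(CCN1CCN(c2ccc(F)cc2)CC1)c1ccc(F)c(Cl)c1` differs from it in one place: 3-chloro-4-fluorophenyl in place of 4-methoxyphenyl on a carbonyl carbon. In short, 3-chloro-4-fluorophenyl stands in place of 4-methoxyphenyl on a carbonyl carbon. The nearest guide is the modest 3.2-fold higher number from compound 1 to compound 3 (0.50 log units; beyond the scatter), where methoxy replaces hydrogen on an aromatic carbon. The large 11-fold higher number from compound 1 to compound 2 (1.03 log units; beyond the scatter) comes from nitro replacing fluoro. Neither step removes the methoxy group or adds chlorine, so both guide only loosely, and no firm direction follows from them. The expected change is small, a 1.1-fold higher number from compound 1 to compound 4 (0.04 log units; within the scatter). Compound 4 is estimated at 60000 nM, with an expected range of 18000 nM to 200000 nM.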

Compound 4, half-maximal inhibitory concentration: 185000 nM
Estimate against measurement, compound 4: 3.1-fold (0.49 log units) below, within the range that was stated.
By their numbers in this assay, from the lowest: compound 1; then compounds 3 and 4 (each within the scatter of the next); then compound 2.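

Among the compounds shown here, compound 3 kept the methoxy group and compound 2 changed a different place, so compound 4 is the first to replace the whole 4-methoxyphenyl group on the carbonyl carbon. In this assay, this replacement gives a 3.4-fold higher number from compound 1 to compound 4 (0.53 log units; beyond the scatter), showing that this place also affects the reading. Nothing available explains the step.

As far as these compounds go, the methoxy group leaves while chlorine and fluorine enter, so the contribution of each remains open. Also open, from the compounds shown here alone, is how a plain phenyl group, or a phenyl group carrying an amine, would read on this carbonyl carbon.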